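A few compounds are considered here, and "the series" means these few. Any claim that something is new, unique, unknown or untested is made for them only; others in the source may bear on it.

Among the measured compounds shown here, compound 3 `C[C@@H]1CN(S(=O)(=O)c2cccc(-c3ccc4nccc(-c5ccncc5)c4n3)c2)C[C@H](C)N1` gives the only plain number among the three values so far: in a physicochemical assay for solubility, read by HPLC, using the shake flask method, measured as kinetic solubility, with a stated time of 20 h, at pH 6.5, tested at 200 uM (a lower number here means a less soluble compound, a higher number a more soluble compound), compound 3 gives 180000 nM. Compound 1 `Nc1cccc(-c2ccc3nccc(-c4ccncc4)c3n2)c1` sits at a limit of this assay, < 5000 nM, not at a number. Compound 2 `NS(=O)(=O)c1cccc(-c2ccc3nccc(-c4ccncc4)c3n2)c1` likewise sits at a limit, < 5000 nM. The steps of an at least 36-fold higher number from compound 1 to compound 3 (1.55 log units; beyond the scatter) and an at least 36-fold higher number from compound 2 to compound 3 (1.55 log units; beyond the scatter) are both read against that limit (the limit of < 5000 nM in this assay, at which 2 of the 3 values shown sit), while the step that the two limits leave unreadable from compound 1 to compound 2 stays hidden behind it. Compound 4 `CS(=O)(=O)Nc1cccc(-c2ccc3nccc(-c4ccncc4)c3n2)c1` is next, with methanesulfonamido in place of (3,5-dimethylpiperazin-1-yl)sulfonyl on an aromatic carbon. The two readable steps point the same way: exchanging amino or sulfamoyl for (3,5-dimethylpiperazin-1-yl)sulfonyl carried the number far past the limit. Compound 4 carries methanesulfonamido instead, a group without a ring, so the step of a 30-fold lower number from compound 3 to compound 4 (1.48 log units; beyond the scatter) is expected to run back down, large, toward where compound 1 and compound 2 sit. For compound 4 the estimate in this assay is 6000 nM, with a range from 1500 nM to 30000 nM, and the measurement may well return only a limit rather than a number.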

Compound 4, solubility: 20000 nM
The estimate for compound 4 lay 3.3-fold (0.52 log units) below the measured number; measured number inside the range.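

Compound 4 gives a second plain number in this assay, so a change on this aromatic carbon can now be sized between two numbers: methanesulfonamido in place of (3,5-dimethylpiperazin-1-yl)sulfonyl gives a 9.0-fold lower number from compound 3 to compound 4 (0.95 log units; beyond the scatter) and stays beyond the scatter. Methanesulfonamido in place of sulfamoyl gives an at least 4.0-fold higher number from compound 2 to compound 4 (0.60 log units; beyond the scatter) and methylsulfonyl in place of hydrogen on a nitrogen on an aromatic ring gives an at least 4.0-fold higher number from compound 1 to compound 4 (0.60 log units; beyond the scatter), and both sizes are read only against a limit: the limit of < 5000 nM in this assay, at which 2 of the 4 values shown sit. Among these four compounds, a plain number therefore does not require the (3,5-dimethylpiperazin-1-yl)sulfonyl group, though compound 3 keeps the highest number.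

From the compounds shown here alone, it remains open whether a morpholine ring or an open-chain amine on the sulfonyl sulfur would fall nearer compound 3 or compound 4. The part played by the ring nitrogen carrying hydrogen in compound 3 also stays unresolved.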